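The source may hold more compounds than are shown below. What is called first, only, known or untested is meant among the compounds shown, and "the series" means these compounds.

Within the data shown here, in a functional assay on DU-145 cells (Homo sapiens) for antiproliferative activity, read by propidium iodide staining, with a stated time of 96 h (on this read-out lower numbers stand for stronger inhibition and higher numbers for weaker inhibition), three compounds have numbers so far. Compound 1 (`CC(O)(COc1cc(C(F)(F)F)cc(C(F)(F)F)c1)C(=O)Nc1cccc(S(F)(F)(F)(F)F)c1`) gives 9300 nM there. Compound 2 (`CC(O)(CS(=O)(=O)c1ccc(S(F)(F)(F)(F)F)cc1)C(=O)Nc1ccc(S(F)(F)(F)(F)F)cc1`) gives 28900 nM there. Compound 3 (`CC(O)(CS(=O)(=O)c1ccc(C(F)(F)F)cc1)C(=O)Nc1ccc(S(F)(F)(F)(F)F)cc1`) gives 29300 nM there, level with compound 2 within the scatter and beyond the scatter from the lower number of compound 1.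

Going from compound 3 to compound 4 (`CC(O)(CS(=O)(=O)c1ccccc1OC(F)(F)F)C(=O)Nc1ccc(S(F)(F)(F)(F)F)cc1`) the change is 2-(trifluoromethoxy)phenyl in place of 4-(trifluoromethyl)phenyl on a sulfonyl sulfur on a sulfonyl sulfur, with 2-(trifluoromethoxy)phenyl in place of 4-(trifluoromethyl)phenyl. Among the measured compounds shown here, the one measured step that touches this aromatic group is a 1.0-fold higher number from compound 2 to compound 3 (0.01 log units; within the scatter) and it lies within the scatter. For the measured compounds named here, that step exchanged one group for another on an aromatic carbon, but no measured step moves a group around this ring or brings in an oxygen, so the support is thin. On that single flat step from compound 2 to compound 3, no shift beyond the scatter is expected in this assay for this change. The expected step is a 1.2-fold lower number from compound 3 to compound 4 (0.07 log units; within the scatter) at most a small one. For compound 4 the estimate is 25000 nM with an expected range from 10000 nM to 60000 nM overall.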

Compound 4, half-maximal inhibitory concentration: 19500 nM
Compound 4: the middle estimate sits 1.3-fold (0.11 log units) above what was measured, within the range that was stated.
By their numbers in this assay, from the lowest: compound 1; then compounds 4, 2 and 3 (each within the scatter of the next).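

On a sulfonyl sulfur, 2-(trifluoromethoxy)phenyl in place of 4-(trifluoromethyl)phenyl gives a 1.5-fold lower number from compound 3 to compound 4 (0.18 log units; within the scatter) in this assay, so this position now has a second step that stays within the scatter. Unlike the step between compound 2 and compound 3, this one changes the name and numbering of the whole aromatic group and brings in an oxygen, and the number still does not move beyond the scatter. No other measurement explains this flatness or says what the oxygen contributes.

The compounds shown leave open whether an amine or a carboxylic acid on this phenyl ring would also leave the number level in this assay as well. They also leave open which of its several differences sets compound 1 apart from compound 3 and compound 4.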